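Changing the Sulfonyl Substituent of Compound 2

The source may report more compounds than this note shows. Statements on the series, on what has been measured and on what is new or still open speak of the compounds shown alone.

In a functional assay on DU-145 cells (Homo sapiens) for inhibition, read by trypan blue exclusion, with a stated time of 72 h (a lower number here means a stronger inhibitor, a higher number a weaker inhibitor), compound 1 `Cn1c(=O)c(S(=O)(=O)Cc2ccc(F)cc2F)cc2cnc(Nc3ccc4[nH]ccc4c3)nc21` gives 1000 nM, and compound 2 `Cn1c(=O)c(S(=O)(=O)c2ccc(Cl)cc2)cc2cnc(Nc3ccc4[nH]ccc4c3)nc21` gives 250 nM, the lower of the two numbers. Compound 3 `Cn1c(=O)c(S(=O)(=O)Nc2ccc(F)cc2)cc2cnc(Nc3ccc4[nH]ccc4c3)nc21` carries (4-fluorophenyl)amino in place of 4-chlorophenyl on a sulfonyl sulfur. Among the measured compounds shown here, the only measured step at this place, a 4.0-fold lower number from compound 1 to compound 2 (0.60 log units; beyond the scatter), is modest but beyond the scatter, and the entering group has no measured precedent. A modest move towards a higher number is therefore expected, and the estimated step is a 1.6-fold higher number from compound 2 to compound 3 (0.20 log units; within the scatter). The expected value for compound 3 is 400 nM, within an estimated range of 120 nM to 1400 nM.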

Compound 3, half-maximal inhibitory concentration: 5000 nM
For compound 3 the middle estimate is 13-fold (1.10 log units) below the measured one; measured number above the stated range.
By their numbers in this assay, from the lowest: compound 2; then compound 1; then compound 3.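

In this assay the swap to (4-fluorophenyl)amino on a sulfonyl sulfur produces a 20-fold higher number from compound 2 to compound 3 (1.30 log units; beyond the scatter) and is large, so this position can move the number much further than the earlier step showed. The same group also gives a 5.0-fold higher number from compound 1 to compound 3 (0.70 log units; beyond the scatter) and places compound 3 last of the three, behind both the 4-chlorophenyl and 2,4-difluorobenzyl groups. The compounds shown leave open whether the amino link or the fluorine accounts for the step. A (4-chlorophenyl)amino group or a 4-fluorophenyl group on the sulfur would separate the two. Nothing given here explains the step.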